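From Butoxy to (Isopropylcarbonyl)oxy on a Shared Core

The compounds below may be only part of what the source reports. "The series", "measured", "known", "first", "only" and "open" are said of these compounds alone.

In a functional assay on DLD-1 cells (Homo sapiens) for cytotoxicity, with a stated time of 48 h (a lower number here means a stronger inhibitor, a higher number a weaker inhibitor), compound 1 (`C[S+]([O-])/C=C/c1cc(=O)c2ccccc2o1`) gives 8000 nM, compound 2 (`CCCCOc1ccc2oc(/C=C/[S+](C)[O-])cc(=O)c2c1`) gives 4800 nM and compound 3 (`COc1cccc2c(=O)cc(/C=C/[S+](C)[O-])oc12`) gives 9000 nM. These three values lie within the scatter of one another, so compound 2 does not stand apart from the other two.

Compound 4 (`CC(C)C(=O)Oc1ccc2oc(/C=C/[S+](C)[O-])cc(=O)c2c1`) carries isopropylcarbonyl in place of butyl on an oxygen on an aromatic ring. Within the data shown here, two measured steps bear on this change. Butoxy in place of hydrogen on an aromatic carbon gives a 1.7-fold lower number from compound 1 to compound 2 (0.22 log units; within the scatter), and methoxy in place of hydrogen on an aromatic carbon gives a 1.1-fold higher number from compound 1 to compound 3 (0.05 log units; within the scatter). Among the measured compounds shown here, both steps stay within the scatter, although no measured compound carries (isopropylcarbonyl)oxy, so this evidence is indirect. A change beyond the scatter in this assay is therefore not expected.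

The expected step is a 1.3-fold higher number from compound 2 to compound 4 (0.10 log units; within the scatter), which would remain within the scatter. For compound 4 the estimated value is 6000 nM, with an expected range of 2500 nM to 14000 nM.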

Compound 4, half-maximal inhibitory concentration: 9100 nM
The estimate for compound 4 lay 1.5-fold (0.18 log units) below the measured number; the range from low to high includes it.
By their numbers in this assay, from the lowest: compounds 2, 1, 3 and 4 (each within the scatter of the next).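

In this assay the exchange of butyl for isopropylcarbonyl on the oxygen gives a 1.9-fold higher number from compound 2 to compound 4 (0.28 log units; within the scatter) and the (isopropylcarbonyl)oxy group in place of hydrogen gives a 1.1-fold higher number from compound 1 to compound 4 (0.06 log units; within the scatter) so both steps stay within the scatter. The earlier compounds shown here showed this only for groups without a carbonyl; compound 4 extends it to an entering group with a carbonyl and a hydrogen-bond acceptor, and compounds 1, 2 and 4 remain within the scatter of one another at this place. Nothing available here explains this outcome.

On these data alone, it remains open whether an amine, a carboxylic acid or a chain longer than butyl at this place would take the number beyond the scatter. The compounds shown also leave open whether any group here can separate itself from the unsubstituted compound 1 at all.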